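The compounds below may be only part of what the source reports. "The series", "measured", "known", "first", "only" and "open" are said of these compounds alone.

Of the compounds shown here, two that share one core have been measured in an assay on isolated protein for inhibition of high affinity 3',5'-cyclic-AMP phosphodiesterase 7A (Homo sapiens), read by cAMP accumulation, with a stated time of 10 min; a higher number here means a weaker inhibitor, a lower number a stronger inhibitor. Compound 1 `COc1nc2c(c(=O)n(C)c(=O)n2C)n1CCCC(=O)Nc1cccc(Cl)c1` gives in this assay only a limit of the assay, > 200000 nM. Compound 2 `COc1nc2c(c(=O)n(C)c(=O)n2C)n1CCCC(=O)Nc1ccc(C(C)C)cc1` also gives in this assay only a limit of the assay, > 200000 nM. For the measured compounds named here, the single step between them, a step that the two limits leave unreadable from compound 1 to compound 2, therefore cannot be read in either direction, and all that the two values show is summed up by the limit of > 200000 nM in this assay, at which 2 of the 2 values shown sit. Compound 2 thus stands at the edge of what this assay can report, with no number of its own to place it.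

Compound 3 `COc1nc2c(c(=O)n(C)c(=O)n2C)n1CCCC(=O)NCc1ccccc1Cl` differs from compound 2 in one place: 2-chlorobenzyl in place of 4-isopropylphenyl on an amide-type nitrogen. Going by the values given here, no measured step bears on this change, since the only step available, a step that the two limits leave unreadable from compound 1 to compound 2, has no readable size. What follows for compound 3 is therefore an estimate with little to rest on, and the step from compound 2 to compound 3 is expected to be a number no higher from compound 2 to compound 3 (the limit leaves the size open). Compound 3 is estimated at 200000 nM, within a range from 30000 nM to 1000000 nM, and most likely the assay will again report only a limit.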

Compound 3, half-maximal inhibitory concentration: > 200000 nM
Compound 3 ended at the assay's limit; the forecaster's own chance of this, stated with the estimate: 75%; the middle value lies on the limit itself.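

In this assay compound 3 gives > 200000 nM, again only a limit of the assay. For the compounds shown here, no step among compound 1, compound 2 and compound 3 can be read, since all the values sit at that limit: the limit of > 200000 nM in this assay, at which 3 of the 3 values shown sit. The compounds shown leave open how 3-chlorophenyl, 4-isopropylphenyl and 2-chlorobenzyl on the amide nitrogen truly differ, and whether any group there on the shared core would give a measurable number.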